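Adding a nitro group to compound 2

The compounds below may be only part of what the source reports. "The series", "measured", "known", "first", "only" and "open" are said of these compounds alone.

Compound 1 `O=C1/C(=C/c2cccnc2)CN(S(=O)(=O)c2ccc([N+](=O)[O-])cc2)C/C1=C\c1ccccc1F` reads > 20000 nM as a limit
Compound 2 `O=C1/C(=C/c2cccnc2)CN(S(=O)(=O)c2ccccc2)C/C1=C\c1ccccc1C(F)(F)F` reads 10900 nM as a number

For the measured compounds named here, in a functional assay on SMMC-7721 cells (Homo sapiens) for cytotoxicity, read by MTT assay, with a stated time of 24 h (on this read-out higher numbers stand for weaker inhibition and lower numbers for stronger inhibition), compound 2 gives 10900 nM, the only exact number so far. For compound 1 the result > 20000 nM is a limit of the assay, not a number.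

Compound 3 `O=C1/C(=C/c2cccnc2)CN(S(=O)(=O)c2ccc([N+](=O)[O-])cc2)C/C1=C\c1ccccc1C(F)(F)F` differs from compound 2 in one place, where phenyl becomes 4-nitrophenyl: nitro in place of hydrogen on an aromatic carbon. The nitro takes the place of hydrogen on an aromatic carbon, para to a large group.

Going by the values given here, no measured pair shows this change alone. Among the compounds with values here, the one measured compound that carries 4-nitrophenyl, compound 1, stands at the limit > 20000 nM, so a modest shift toward weaker inhibition in this assay is expected. The estimated step of a 1.3-fold higher number from compound 2 to compound 3 (0.11 log units; within the scatter) is small and may not clear the usual scatter. Compound 3 is expected at about 14000 nM, with an estimated range of 6000 nM to 28000 nM.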

Compound 3, half-maximal inhibitory concentration: 15900 nM
For compound 3 the middle estimate is 1.1-fold (0.06 log units) below the measured one, within the range that was stated.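

Nitro in place of hydrogen on an aromatic carbon of the phenylsulfonyl group gives a 1.5-fold higher number from compound 2 to compound 3 (0.16 log units; within the scatter) in this assay, so this first exact comparison shows no change that clears the scatter. Trifluoromethyl in place of fluoro on an aromatic carbon gives an at least 1.2-fold lower number from compound 1 to compound 3 (0.09 log units; that floor lies within the scatter), which is a floor and also does not clear the scatter. The true size of that second step stays unknown because compound 1 reads as a limit of the assay, not a number: the limit of > 20000 nM in this assay, at which 1 of the 3 values shown sits.

The compounds shown leave open whether an amine or a carboxylic acid in place of the nitro would move the number beyond the scatter. They also leave open how a methoxy group on that same aromatic carbon would read.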